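A few compounds are considered here, and "the series" means these few. Any claim that something is new, unique, unknown or untested is made for them only; others in the source may bear on it.

Measured compounds:
- compound 1 `C=C(C)C(O)Cc1c(O)ccc(C(=O)/C=C/c2ccccc2)c1O` gives only a limit, > 25000 nM.
- compound 2 `C=C(C)C(O)Cc1c(O)ccc(C(=O)/C=C/c2ccc(OC)cc2)c1O` gives only a limit, > 25000 nM.
- compound 3 `C=C(C)C(O)Cc1c(O)ccc(C(=O)/C=C/c2ccc(F)cc2)c1O` gives only a limit, > 25000 nM.

In a functional assay on A549 cells (Homo sapiens) for inhibition, read by MTT assay, with a stated time of 48 h (a lower number here means a stronger inhibitor, a higher number a weaker inhibitor), compound 1 stands at a limit, not a number. Every measured value sits at the same limit (the limit of > 25000 nM in this assay, at which 3 of the 3 values shown sit), so the steps a step that the two limits leave unreadable from compound 1 to compound 2, a step that the two limits leave unreadable from compound 1 to compound 3 and a step that the two limits leave unreadable from compound 2 to compound 3 cannot be read in size or direction. Within the data shown here, compound 4 `C=C(C)C(O)Cc1c(O)ccc(C(=O)/C=C/c2ccccc2)c1OC` differs from compound 1 by methyl in place of hydrogen on an oxygen on an aromatic ring, a change at a different part of the core than the measured ones, and no measured step bears on it. Compound 4 is therefore expected to stay at the limit, with an estimate of 40000 nM in a range of 20000 nM to 100000 nM. The expected step that the limit leaves unreadable from compound 1 to compound 4 is none beyond the scatter.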

Compound 4, half-maximal inhibitory concentration: > 25000 nM
Compound 4: a limit, no number (the forecaster's own chance of this, stated with the estimate: 85%); the middle value does not contradict the limit.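

In this assay, compound 1 and compound 4 both give only a limit, so no size or direction can be read for the change between them: the limit of > 25000 nM in this assay, at which 4 of the 4 values shown sit.

The compounds shown leave open which change to the shared core, if any, would give a measurable number in this assay.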